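Trimethylphenyl versus methoxy-methylphenyl analogues: antiproliferative notes

The source may report more compounds than this note shows. Statements on the series, on what has been measured and on what is new or still open speak of the compounds shown alone.

Measured so far:
compound 1, `CCC1=C(O)c2c(oc(-c3ccc(C)c(C)c3)cc2=O)C(CC)(CC)C1=O`: 35.5 uM
compound 2, `CCC1=C(O)c2c(oc(-c3cc(C)c(C)cc3C)cc2=O)C(CC)(CC)C1=O`: 8.2 uM
compound 3, `CCC1=C(O)c2c(oc(-c3ccc(OC)c(C)c3)cc2=O)C(CC)(CC)C1=O`: 28.5 uM

In a functional assay on KB cells (Homo sapiens) for antiproliferative activity, read by sulforhodamine B assay, with a stated time of 3 days (a lower number here means that less compound is needed, a higher number that more compound is needed for the effect), the series gives the numbers above. The change from compound 1 to compound 2 is methyl in place of hydrogen on an aromatic carbon and gave a 4.3-fold lower number from compound 1 to compound 2 (0.64 log units; beyond the scatter). The change from compound 1 to compound 3 is methoxy in place of methyl on an aromatic carbon and gave a 1.2-fold lower number from compound 1 to compound 3 (0.10 log units; within the scatter). Between compound 2 and compound 3 the step is a 3.5-fold higher number from compound 2 to compound 3 (0.54 log units; beyond the scatter).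

Compound 4, `CCC1=C(O)c2c(oc(-c3ccc(OC)c(C)c3C)cc2=O)C(CC)(CC)C1=O`, is not yet measured. Its difference from compound 3 is methyl in place of hydrogen on an aromatic carbon. This is the same kind of change as that from compound 1 to compound 2, but the surroundings differ: in compound 2 the entering methyl is meta to a methyl group and para to a methyl group, whereas in compound 4 it is ortho to a methyl group and meta to a methoxy group. A step of similar direction but somewhat smaller size is expected, a 2.9-fold lower number from compound 3 to compound 4 (0.45 log units; beyond the scatter), resting on a 4.3-fold lower number from compound 1 to compound 2 (0.64 log units; beyond the scatter) applied to compound 3 at 28.5 uM. Compound 4 is therefore estimated at 10 uM in this assay, between 4 uM and 25 uM.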

Compound 4, concentration for half-maximal effect: 5.43 uM
Estimate against measurement, compound 4: 1.8-fold (0.27 log units) above; the measured number falls inside the stated range.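

In this assay, methyl in place of hydrogen on an aromatic carbon gives a 5.2-fold lower number from compound 3 to compound 4 (0.72 log units; beyond the scatter), and this step matches the earlier one on the other core: the same change on two cores in this assay, a 4.3-fold lower number (0.64 log units; beyond the scatter) from compound 1 to compound 2 and a 5.2-fold lower number (0.72 log units; beyond the scatter) from compound 3 to compound 4, 1.2-fold (0.08 log units) apart, within the scatter of two such steps

The size of the step therefore carries from the core of compound 1 to the core of compound 3, even though the entering methyl in compound 4 is ortho to a methyl group and meta to a methoxy group, a different setting from that in compound 2. This rests on two matched pairs in one cell assay, so it shows neither why the step is so similar nor that it would hold on further cores or at other ring positions.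

Still open, as far as these compounds go, is how a longer chain, a chlorine atom or an amine would behave on an aromatic carbon where the methyl enters. Also open is whether the same step would appear in cell lines other than the one shown here.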